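Swapping an ethyl for an acetyl on the ring oxygen

The compounds below may be only part of what the source reports. "The series", "measured", "known", "first", "only" and "open" are said of these compounds alone.

Three close relatives share one core and differ only in a single group on an aromatic carbon. Compound 1 `CC(C)(C)c1cc(NC(=O)Nc2ccc(-c3cn4ccc(Cl)cc4n3)cc2)no1` carries a chloro there and gives 5.91 nM in a functional assay on MV4-11 cells (Homo sapiens) for cytotoxicity, read by MTT assay, with a stated time of 72 h; a lower number here means a stronger inhibitor, a higher number a weaker inhibitor. Compound 2 `C#Cc1ccn2cc(-c3ccc(NC(=O)Nc4cc(C(C)(C)C)on4)cc3)nc2c1` carries an ethynyl and gives 3.46 nM. Compound 3 `CCOc1ccn2cc(-c3ccc(NC(=O)Nc4cc(C(C)(C)C)on4)cc3)nc2c1` carries an ethoxy and gives 11.6 nM, the highest of the three numbers, although its gap to compound 1 lies within the scatter while its gap to compound 2 lies beyond it.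

Compound 4 `CC(=O)Oc1ccn2cc(-c3ccc(NC(=O)Nc4cc(C(C)(C)C)on4)cc3)nc2c1` is the next step from compound 3: acetyl in place of ethyl on an oxygen on an aromatic ring. Within the data shown here, no measured pair shows this exact swap. The two steps that touch the same place are a 2.0-fold higher number from compound 1 to compound 3 (0.29 log units; within the scatter) and a 3.4-fold higher number from compound 2 to compound 3 (0.53 log units; beyond the scatter), both pointing to weaker inhibition when the ethoxy arrives. Whether lengthening that oxygen substituent into an ester moves the number further is not known from these data, so the expectation for compound 4 leans on compound 3 alone and allows for a modest step in either direction.

Compound 4 is therefore expected to land near 15 nM, with a plausible range from 5 nM to 45 nM. The implied step is estimated as a 1.3-fold higher number from compound 3 to compound 4 (0.11 log units; within the scatter).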

Compound 4, half-maximal inhibitory concentration: 29.4 nM
Compound 4: middle estimate off by 2.0-fold (0.29 log units), on the low side; the range from low to high includes it.
By their numbers in this assay, from the lowest: compounds 2, 1 and 3 (each within the scatter of the next, the first and the last beyond it); then compound 4.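

In this assay, among these compounds, the earlier steps replaced the whole group on the aromatic carbon, so they could not separate the effect of the oxygen from the effect of what it carries. Compounds 3 and 4 keep that oxygen and change only its outer part, and acetyl in place of ethyl still gives a 2.5-fold higher number from compound 3 to compound 4 (0.40 log units; beyond the scatter), so the outer part alone can move the number beyond the scatter. The acetoxy group also gives the weakest inhibitor of the four, with a 5.0-fold higher number from compound 1 to compound 4 (0.70 log units; beyond the scatter) and an 8.5-fold higher number from compound 2 to compound 4 (0.93 log units; beyond the scatter), which shows that the choice of group at this position spans a wider range than the first three compounds revealed.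

Nothing available explains why the acetyl gives a higher number than the ethyl. Going by these compounds, it also remains open whether this trend has any wider reach, for example whether a longer chain on the oxygen would raise the number further, or where a hydroxyl or an amine in place of the whole group would fall.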